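A Fluorine Placed Differently on the Same Ring

A few compounds are considered here, and "the series" means these few. Any claim that something is new, unique, unknown or untested is made for them only; others in the source may bear on it.

Of the compounds shown here, three sharing one core have been tested in a functional assay on the whole organism with Mus musculus as the target; on this read-out lower numbers stand for an effect already at smaller amounts and higher numbers for an effect only at larger amounts of compound. Compound 1 `CC1(C)OC(C)(C)c2c1nnc(-c1ccccc1)[n+]2[O-]` carries an unsubstituted phenyl group and gives 163 mg/kg. Compound 2 `CC1(C)OC(C)(C)c2c1nnc(-c1cccc(Cl)c1)[n+]2[O-]` bears a chloro group on that ring and gives 500 mg/kg, so that a 3.1-fold higher number from compound 1 to compound 2 (0.49 log units; beyond the scatter). Compound 3 `CC1(C)OC(C)(C)c2c1nnc(-c1cccc(F)c1)[n+]2[O-]` carries a fluoro group instead and gives 74.9 mg/kg; this is the lowest number of the three, since a 2.2-fold lower number from compound 1 to compound 3 (0.34 log units; beyond the scatter) and a 6.7-fold lower number from compound 2 to compound 3 (0.82 log units; beyond the scatter). Compound 4 `CC1(C)OC(C)(C)c2c1nnc(-c1ccc(F)cc1)[n+]2[O-]` has not yet been measured. The change from compound 3 to compound 4 is 4-fluorophenyl in place of 3-fluorophenyl on an aromatic carbon. For the measured compounds named here, none of the measured steps shows what happens when the fluorine sits elsewhere on this ring; the steps ending at compound 3 only show that fluoro lowers the number compared with hydrogen and with chloro. The step is therefore expected to be small, a 1.3-fold higher number from compound 3 to compound 4 (0.13 log units; within the scatter), and could fall in either direction. For compound 4 the estimate in this assay is 100 mg/kg, within a range from 40 mg/kg to 250 mg/kg.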

Compound 4, dose for half-maximal effect: 500 mg/kg
The estimate for compound 4 lay 5.0-fold (0.70 log units) below the measured number; measured number outside the range, above it.
By their numbers in this assay, from the lowest: compound 3; then compound 1; then compounds 2 and 4 (each within the scatter of the next).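

Moving the fluorine is not a neutral swap in this assay even though the atoms stay the same: going from 3-fluorophenyl to 4-fluorophenyl costs a clear step (a 6.7-fold higher number from compound 3 to compound 4 (0.82 log units; beyond the scatter)). Fluoro on this ring therefore does not lower the number by itself, since 4-fluorophenyl moves it the opposite way from hydrogen (a 3.1-fold higher number from compound 1 to compound 4 (0.49 log units; beyond the scatter)), and the result cannot be told apart from that of the 3-chlorophenyl group (no change at the digits printed from compound 2 to compound 4 (within the scatter)). Nothing available here explains why the site of the fluorine matters so much.

Going by these compounds, it remains open whether other groups on this ring, such as a methoxy group, a nitrile or an amine, depend as strongly on where they sit. The same question applies to any change made to the shared core itself.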